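The source may report more compounds than this note shows. Statements on the series, on what has been measured and on what is new or still open speak of the compounds shown alone.

Measured compounds:
Compound 1, `Cn1cncc1CN1CC(N(CC2CCN(C(=O)Nc3ccc(Br)cc3)CC2)S(=O)(=O)c2ccccn2)Cc2cc(C#N)ccc21`, in an ADME assay on Caco-2 cells (Homo sapiens) for permeability, in the apical to basolateral direction (a lower number here means that the compound crosses the layer more slowly, a higher number that the compound crosses the layer faster), gives 0.6 10^-6 cm/s.
Compound 2, `Cn1cncc1CN1CC(N(CC2CCN(C(=O)c3ccco3)CC2)S(=O)(=O)c2ccccn2)Cc2cc(C#N)ccc21`, in this assay gives 0.5 10^-6 cm/s.
Compound 3, `Cn1cncc1CN1CC(N(Cc2cccc(-n3cccc3)c2)S(=O)(=O)c2ccccn2)Cc2cc(C#N)ccc21`, in this assay gives 2.3 10^-6 cm/s.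

Compound 3 stands highest of the three on this assay; compound 1 lies nearest with a number well below it, and compound 2 lies furthest, also beyond the scatter. Going by the values given here, the only step between measured compounds, a 1.2-fold lower number from compound 1 to compound 2 (0.08 log units; within the scatter), is within the scatter and concerns the carbonyl carbon, a place that does not change on the way to compound 4, so it bears on the new step only indirectly.

Compound 4, `CCNC(=O)N1CCC(CN(C2Cc3cc(C#N)ccc3N(Cc3cncn3C)C2)S(=O)(=O)c2ccccn2)CC1`, differs from compound 3 in one place: 1-(ethylcarbamoyl)piperidin-4-yl in place of 3-(1H-pyrrol-1-yl)phenyl on a saturated chain carbon bound to a sulfonamide nitrogen. Compounds 1 and 2 both carry a piperidin-4-yl group bearing a carbonyl on the same saturated chain carbon bound to the sulfonamide nitrogen, and both sit far below compound 3. Compound 4 is therefore expected to fall back toward those two numbers, with a 3.8-fold lower number from compound 3 to compound 4 (0.58 log units; beyond the scatter) as the expected step, a decrease beyond the scatter. The estimate for compound 4 in this assay is 0.6 10^-6 cm/s, in a range from 0.3 10^-6 cm/s to 1.3 10^-6 cm/s.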

Compound 4, apparent permeability: 0.6 10^-6 cm/s
The estimate for compound 4 equals the measured number at the digits printed, within the range that was stated.
By their numbers in this assay, from the lowest: compounds 2, 1 and 4 (each within the scatter of the next); then compound 3.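

In this assay, going by these compounds alone, the first single-place change at the saturated chain carbon bound to a sulfonamide nitrogen gives a 3.8-fold lower number from compound 3 to compound 4 (0.58 log units; beyond the scatter) and so ties the lower number directly to 1-(ethylcarbamoyl)piperidin-4-yl replacing 3-(1H-pyrrol-1-yl)phenyl. Once that group is in place, the part on its carbonyl carbon matters little here: ethylamino in place of furan-2-yl gives a 1.2-fold higher number from compound 2 to compound 4 (0.08 log units; within the scatter) and ethyl in place of 4-bromophenyl on the amide-type nitrogen gives no change at the digits printed from compound 1 to compound 4 (within the scatter) and both lie within the scatter. No supporting evidence on the cause of the step from compound 3 accompanies these numbers.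

The compounds shown leave open where a plain phenyl on the same carbon would fall. They also leave open whether a piperidin-4-yl carrying a free amine nitrogen, with no carbonyl, would stay with compound 4 or move toward compound 3.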